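Working notes: chloro in place of methoxy

The source may report more compounds than this note shows. Statements on the series, on what has been measured and on what is new or still open speak of the compounds shown alone.

Measured so far in an ADME assay for permeability, using PAMPA, at pH 4 (on this read-out higher numbers stand for higher permeability and lower numbers for lower permeability), are two compounds:
- compound 1 `Cc1[nH]c2ccc(Cl)cc2c(=O)c1Cc1ccccc1` at 422 10^-6 cm/s
- compound 2 `COc1ccc2c(c1)c(=O)c(Cc1ccccc1)c(C)n2C` at 295 10^-6 cm/s

Compound 2 at 295 10^-6 cm/s stands within the usual scatter of compound 1 at 422 10^-6 cm/s and the two cannot be ranked. The next compound is compound 3 `Cc1c(Cc2ccccc2)c(=O)c2cc(Cl)ccc2n1C` which carries chloro in place of methoxy on an aromatic carbon relative to compound 2. For the measured compounds named here, no measured pair differs in one place only, so the data show no size for this kind of step. In this assay no change beyond the scatter is expected, with at most a slight upward drift. The estimated move a 1.2-fold higher number from compound 2 to compound 3 (0.07 log units; within the scatter) is expected to be of that small size. On this basis compound 3 is estimated at 350 10^-6 cm/s with an expected range of 170 10^-6 cm/s to 650 10^-6 cm/s for the measurement.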

Compound 3, apparent permeability in the ADME assay: 510 10^-6 cm/s
Compound 3: middle estimate off by 1.5-fold (0.16 log units), on the low side; measured number inside the range.
By their numbers in the ADME assay, from the lowest: compounds 2, 1 and 3 (each within the scatter of the next).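

In the ADME assay, chloro in place of methoxy on an aromatic carbon now has a measured size, a 1.7-fold higher number from compound 2 to compound 3 (0.24 log units; within the scatter), and methyl in place of hydrogen on an aromatic nitrogen has one too, a 1.2-fold higher number from compound 1 to compound 3 (0.08 log units; within the scatter), so neither change separates its pair on this read-out. In a physicochemical assay for lipophilicity, at pH 7.4 (on this read-out lower numbers stand for lower lipophilicity and higher numbers for higher lipophilicity), compound 2 gives 2.73 and compound 3 gives 3.21 on this read-out. In the physicochemical assay, the change from methoxy to chloro does separate the pair, and compound 3 is the more lipophilic of the two: the measured distribution coefficient of compound 2, 2.73, and of compound 3, 3.21, a number 0.48 log units higher (beyond the scatter) For this one pair, a step beyond the scatter on that read-out therefore comes with a step within the scatter in the ADME assay.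

From the compounds shown here alone, whether an amine or a carboxylic acid at this aromatic carbon would give a step beyond the scatter in the ADME assay stays open. Going by these compounds, with a single pair for each change, it is also open whether these step sizes hold on any other core.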